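The compounds below may be only part of what the source reports. "The series", "measured", "known", "first", "only" and "open" are said of these compounds alone.

Measured in a functional assay on L1210 cells (Mus musculus), read by MTT assay; a lower number here means a stronger inhibitor, a higher number a weaker inhibitor:
- compound 1 `CCC#C[C@@]1(O)[C@@H](CO)O[C@@H](n2ccc(N)nc2=O)[C@@H]1O`: 129000 nM
- compound 2 `CCC[C@@]1(O)[C@@H](CO)O[C@@H](n2ccc(=O)[nH]c2=O)[C@@H]1O`: > 350000 nM (a limit)
- compound 3 `C#C[C@H]1[C@@H](O)[C@H](n2ccc(=O)[nH]c2=O)O[C@@H]1CO`: > 350000 nM (a limit)

Of these three, only compound 1 returns an actual number. Compound 3 has no number, and its > 350000 nM is a limit of the assay. It sits at the limit of > 350000 nM in this assay, at which 2 of the 3 values shown sit, and compound 2 sits there with it.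

The next compound is compound 4 `C#C[C@@H]1[C@@H](O)[C@H](n2ccc(=O)[nH]c2=O)O[C@@H]1CO`, which is related to compound 3 by a single change: the two compounds have the same atoms and bonds and differ only in configuration as drawn: 1 of 4 stereo elements differ; a stereocentre at a saturated ring carbon is drawn S in compound 3 and R in compound 4. A stereocentre at a saturated ring carbon is drawn S in compound 3 and R in compound 4, and nothing else differs.

For the measured compounds named here, no measured step shows what such an inversion does in this assay, so no step beyond the scatter is expected, in either direction. The estimated change is a number no higher from compound 3 to compound 4 (the limit leaves the size open). Compound 4 may well be reported only as a limit too. For compound 4 the expected value is 350000 nM, with an estimated range of 150000 nM to 700000 nM.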

Compound 4, half-maximal inhibitory concentration: > 350000 nM
Compound 4 was reported as a limit; the forecaster's own chance of this, stated with the estimate: 75%; the middle value lies on the limit itself.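

In this assay, for the compounds shown here, compound 4 gives > 350000 nM, which is a limit and not a number; compound 3 also stands at a limit, so no step between compound 3 and compound 4 can be read. As far as these compounds go, whether inverting this stereocentre changes activity at all, and in which direction, remains open.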